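A few compounds are considered here, and "the series" means these few. Any claim that something is new, unique, unknown or untested is made for them only; others in the source may bear on it.

Compound 1, `CCCCn1ncc(OCc2nnc(-c3ccccc3)o2)c(Cl)c1=O`, gives > 299000 nM in a functional assay on the whole organism for inhibition, with Mythimna separata as the target, with a stated time of 5 days (a higher number here means that more compound is needed for the effect, a lower number that less compound is needed), which is a limit of the assay. Compound 2, `CCCCn1ncc(OCc2nnc(-c3ccc(F)cc3)o2)c(Cl)c1=O`, gives 161000 nM in this assay. Compound 3, `CCCCn1ncc(OCc2nnc(-c3ccc(Cl)cc3)o2)c(Cl)c1=O`, gives 223000 nM in this assay.

Compound 1 thus stands only at a limit, (the limit of > 299000 nM in this assay, at which 1 of the 3 values shown sits), and the two steps that start from it, an at least 1.8-fold lower number from compound 1 to compound 2 (0.26 log units; that floor lies within the scatter) and an at least 1.3-fold lower number from compound 1 to compound 3 (0.12 log units; that floor lies within the scatter), both place a halogen on the phenyl ring in place of hydrogen. Compound 4, `O=c1c(Cl)c(OCc2nnc(-c3ccccc3)o2)cnn1-c1ccccc1`, differs from compound 1 by phenyl in place of butyl on an aromatic nitrogen. For the measured compounds named here, no measured step touches this position, so the measured steps give no expectation of a step in either direction beyond the scatter. Compound 4 is therefore expected to remain weak, estimated at 250000 nM with a range from 60000 nM to 1000000 nM. This estimate means an expected step of an at least 1.1-fold lower number from compound 1 to compound 4 (0.07 log units; that floor lies within the scatter).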

Compound 4, half-maximal effective concentration: 91400 nM
Compound 4: the middle estimate sits 2.7-fold (0.44 log units) above what was measured; the range from low to high includes it.
By their numbers in this assay, from the lowest: compounds 4, 2 and 3 (each within the scatter of the next, the first and the last beyond it). At a limit, above all of these: compound 1.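

Phenyl in place of butyl on the aromatic nitrogen gives an at least 3.2-fold lower number from compound 1 to compound 4 (0.51 log units; beyond the scatter), the first step at this position and the only one shown that lies beyond the scatter. This position can therefore shift the number in this assay, and an aromatic ring is accepted there. The true size of the step stays unknown, and its printed size is only a floor, since compound 1 stands at a limit: the limit of > 299000 nM in this assay, at which 1 of the 4 values shown sits.

The compounds shown leave open whether the aromatic ring itself or simply the larger group carries the step; a cyclohexyl ring or a hexyl chain on this nitrogen would separate the two. From the compounds shown here alone, it also stays open whether fluoro or chloro on the other phenyl ring would add to this change.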